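Methoxy on a Pendant Phenyl Ring: One Change, Two Settings

This account rests on a few compounds, and the source may have more. Where it says the series, first, only, none or still open, it means among the compounds named here.

Measured compounds:
- Compound 1 `COc1ccc(CSC2c3cc(OC)cc(OC)c3[C@@H](c3ccc(OC)cc3)[C@@H]2c2cc(OC)cc(OC)c2)cc1`: 12500 nM
- Compound 2 `COc1ccc([C@@H]2c3c(OC)cc(OC)cc3C(SCc3ccccc3)[C@H]2c2cc(OC)cc(OC)c2)cc1`: > 200000 nM
- Compound 3 `COc1cc(OC)cc([C@@H]2C(C(O)c3ccccc3)c3cc(OC)cc(OC)c3[C@H]2c2ccccc2)c1`: 21600 nM

In a functional assay on RAW264.7 cells (Mus musculus) for inhibition, with stated times of 2 h and 24 h (a lower number here means a stronger inhibitor, a higher number a weaker inhibitor), compound 1 gives 12500 nM. For compound 2 the assay reports only a limit, > 200000 nM, not a number. Compound 3 gives 21600 nM in this assay, and its value and that of compound 1 lie within the scatter of each other, so no order between them can be read.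

Compound 1 and compound 2 differ in one place: methoxy in place of hydrogen on an aromatic carbon. That change brought an at least 16-fold lower number from compound 2 to compound 1 (1.20 log units; beyond the scatter). Its size is known only as a minimum because the limit of > 200000 nM in this assay, at which 1 of the 3 values shown sits, sets the starting point.

Compound 3 has a different core from compound 2; the difference between the two cores is not broken down here. Compound 4 `COc1ccc(C(O)C2c3cc(OC)cc(OC)c3[C@@H](c3ccccc3)[C@@H]2c2cc(OC)cc(OC)c2)cc1` differs from compound 3 by methoxy in place of hydrogen on an aromatic carbon. The place of the change is the same in both pairs, but the group carrying it differs: in the first pair a benzylsulfanyl group becomes a (4-methoxybenzyl)sulfanyl group, while in the second a hydroxy(phenyl)methyl group becomes a hydroxy(4-methoxyphenyl)methyl group.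

Given that the same change from compound 2 to compound 1 gave an at least 16-fold lower number from compound 2 to compound 1 (1.20 log units; beyond the scatter), compound 4 is expected to give a lower number than compound 3, though with a different surrounding group the step is expected to be smaller, about a 3.1-fold lower number from compound 3 to compound 4 (0.49 log units; beyond the scatter). Compound 4 is therefore estimated at 7000 nM, between 2000 nM and 25000 nM.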

Compound 4, half-maximal inhibitory concentration: 16500 nM
Estimate against measurement, compound 4: 2.4-fold (0.37 log units) below; the range from low to high includes it.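

In this assay, the methoxy change gave a 1.3-fold lower number from compound 3 to compound 4 (0.12 log units; within the scatter), so in this pair its effect cannot be told apart from the ordinary variation between repeated measurements. The same change therefore did not carry over at the size seen in the first pair, and the two steps differ by more than that variation allows: the same change on two cores in this assay, an at least 16-fold lower number (1.20 log units; beyond the scatter) from compound 2 to compound 1 and a 1.3-fold lower number (0.12 log units; within the scatter) from compound 3 to compound 4, at least 12-fold (1.08 log units) apart, beyond the scatter of two such steps

This does not show why the two pairs part, as they differ from each other in more than the group that carries the new methoxy, and the true size of the first step also remains unknown, as compound 2 has only a limit: the limit of > 200000 nM in this assay, at which 1 of the 4 values shown sits.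

The compounds shown leave open whether another group in the same place on the phenyl ring, such as an amine or a carboxylic acid, would also give a large step with a benzylsulfanyl group and little or none with a hydroxy(phenyl)methyl group. They also leave open whether the methoxy change would behave alike on these two groups if the rest of the molecule were identical, which would separate the role of the carrying group from that of the other differences.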